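This account rests on a few compounds, and the source may have more. Where it says the series, first, only, none or still open, it means among the compounds named here.

Working notes on the series. Compound 3 `c1ccc(-c2ccccc2NCC2=NCCN2)nc1` is measured in a functional assay for activation of Alpha-1D adrenergic receptor (Homo sapiens) (on this read-out higher numbers stand for an effect only at larger amounts of compound and lower numbers for an effect already at smaller amounts), at 41.7 nM. Compound 2 `Cc1ccsc1-c1ccccc1NCC1=NCCN1` gives 49 nM in this assay, and the pair sits within the scatter of each other, as shown by a 1.2-fold lower number from compound 2 to compound 3 (0.07 log units; within the scatter). Compound 1 `Cc1nc(-c2ccccc2NCC2=NCCN2)co1` gives only < 5020 nM in this assay, which is a limit and not a number. The steps from compound 1 to the others cannot be sized because of the limit of < 5020 nM in this assay, at which 1 of the 3 values shown sits: a step that the limit leaves unreadable from compound 1 to compound 2 and a step that the limit leaves unreadable from compound 1 to compound 3 remain unreadable. Compound 3 therefore stands beside compound 2 on the two readable numbers, with the third value being a limit.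

Compound 4 `FC(F)(F)c1cccnc1-c1ccccc1NCC1=NCCN1` is the next compound to be measured in this assay. It differs from compound 3 by trifluoromethyl in place of hydrogen on an aromatic carbon. For the measured compounds named here, none of the measured steps touches this kind of change; all three exchange the whole aromatic substituent rather than adding a group to the pyridin-2-yl ring, so no measured step bears directly on it. The expectation for compound 4 is therefore anchored on compound 3 alone and is a modest shift of a 1.9-fold higher number from compound 3 to compound 4 (0.28 log units; within the scatter) at most. Compound 4 is estimated to give 80 nM in this assay, within a range from 20 nM to 400 nM.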

Compound 4, half-maximal effective concentration: < 100000 nM
Compound 4: a limit, no number; the forecaster's own chance of this, stated with the estimate: 10%; the middle value does not contradict the limit.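

Compound 4 gives only a limit in this assay, not a number, so the step from compound 3 to compound 4 cannot be read: the limit of < 100000 nM in this assay, at which 1 of the 4 values shown sits.

The compounds shown leave open whether trifluoromethyl in place of hydrogen on the pyridin-2-yl ring of compound 3 changes the result in this assay, and if so, in which direction and by how much.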